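From Isopropylamino to Azetidin-1-yl on the Carbonyl

This account rests on a few compounds, and the source may have more. Where it says the series, first, only, none or still open, it means among the compounds named here.

In a functional assay on MDA-MB-468 cells (Homo sapiens) for antiproliferative activity, read by sulforhodamine B assay, with a stated time of 4 days (a higher number here means a weaker inhibitor of growth, a lower number a stronger inhibitor of growth), compound 2 `COc1cc(Cl)c(-c2nc(SCC(=O)NC(C)C)nc3[nH]cc(C#N)c23)cc1O` gives 178 nM, within the scatter of both of its measured neighbours: compound 1 `COc1cc(Cl)c(-c2nc(SCC(=O)NC3CC3)nc3[nH]cc(C#N)c23)cc1O` at 236 nM and compound 3 `COc1cc(Cl)c(-c2nc(SCC(=O)NC(C)C)nc3[nH]cc(C#N)c23)cc1OC` at 102 nM. Compound 4 `COc1cc(Cl)c(-c2nc(SCC(=O)N3CCC3)nc3[nH]cc(C#N)c23)cc1O` carries azetidin-1-yl in place of isopropylamino on a carbonyl carbon. The closest measured change, on the same amide-type nitrogen, is a 1.3-fold lower number from compound 1 to compound 2 (0.12 log units; within the scatter). The change on an aromatic oxygen, a 1.7-fold lower number from compound 2 to compound 3 (0.24 log units; within the scatter), is made at a different place and bears on this one less. Going by the values given here, no measured compound carries azetidin-1-yl, so the evidence is indirect. Only a small change, no larger than the scatter, is therefore expected in this assay, with the expected step being a 1.2-fold higher number from compound 2 to compound 4 (0.09 log units; within the scatter). Compound 4 is estimated at 220 nM, with an expected range of 80 nM to 600 nM.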

Compound 4, concentration for 50% growth inhibition: 28 nM
Estimate against measurement, compound 4: 7.9-fold (0.90 log units) above; measured number outside the range, below it.
By their numbers in this assay, from the lowest: compound 4; then compounds 3, 2 and 1 (each within the scatter of the next, the first and the last beyond it).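

On this carbonyl carbon, azetidin-1-yl brings the only steps beyond the scatter among these compounds in this assay: a 6.4-fold lower number from compound 2 to compound 4 (0.80 log units; beyond the scatter) and an 8.4-fold lower number from compound 1 to compound 4 (0.93 log units; beyond the scatter). Azetidin-1-yl has the same count of heavy atoms as isopropylamino, but it has a four-membered ring and 0 hydrogen-bond donors where isopropylamino has no ring and 1 donor, so the change in shape and donor count, not in atom count, goes with this step. Nothing given here explains the gain. Still open, on these data alone, is whether a pyrrolidine or piperidine ring, or dimethylamino without a ring, would do the same. Also open, as far as these compounds go, is whether azetidin-1-yl keeps its gain with the methyl on the aromatic oxygen of compound 3.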